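Replacing the Hydroxyhexyl Ester of Compound 3 with an Oxanyl Ester

A few compounds are considered here, and "the series" means these few. Any claim that something is new, unique, unknown or untested is made for them only; others in the source may bear on it.

Three esters built on one shared core have been tested in a functional assay on DU-145 cells (Homo sapiens) for cytotoxicity, read by MTT assay; on this read-out lower numbers stand for stronger inhibition and higher numbers for weaker inhibition. Compound 1 `CC(C)=CC[C@@H](OC(=O)c1ccco1)C1=CC(=O)c2c(O)ccc(O)c2C1=O` carries a furan-2-yl group on the ester carbonyl carbon; in this assay compound 1 reaches only the limit of > 100000 nM. Compound 2 `CCCC(O)CC(=O)O[C@H](CC=C(C)C)C1=CC(=O)c2c(O)ccc(O)c2C1=O`, with a 2-hydroxypentyl group in that place, likewise gives only the limit of > 100000 nM. Going by the values given here, compound 3 `CCCCC(O)CC(=O)O[C@H](CC=C(C)C)C1=CC(=O)c2c(O)ccc(O)c2C1=O` is the sole compound with an actual number, giving 45300 nM in this assay. The step of an at least 2.2-fold lower number from compound 1 to compound 3 (0.34 log units; beyond the scatter) and the step of an at least 2.2-fold lower number from compound 2 to compound 3 (0.34 log units; beyond the scatter) both point toward compound 3, though both rest on the limit of > 100000 nM in this assay, at which 2 of the 3 values shown sit, and their true size is therefore not readable.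

Compound 4 `CC(C)=CC[C@@H](OC(=O)C1CCCOC1)C1=CC(=O)c2c(O)ccc(O)c2C1=O` has not yet been measured. It differs from compound 3 in one place: oxan-3-yl in place of 2-hydroxyhexyl on a carbonyl carbon. The hydroxyl-bearing chain that set compound 3 apart from compound 1 in an at least 2.2-fold lower number from compound 1 to compound 3 (0.34 log units; beyond the scatter) is given up for a ring, and compound 1, the other ring-bearing ester, sat at the limit. The account therefore expects compound 4 to move back toward weaker inhibition, with an estimated step of a 2.4-fold higher number from compound 3 to compound 4 (0.39 log units; beyond the scatter) in this assay. The estimated value for compound 4 is 110000 nM, expected to fall between 40000 nM and 300000 nM.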

Compound 4, half-maximal inhibitory concentration: 29700 nM
Compound 4: the middle estimate sits 3.7-fold (0.57 log units) above what was measured; measured number below the stated range.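

In this assay this place on the carbonyl carbon does not depend on the hydroxyl-bearing chain: oxan-3-yl, with 0 hydrogen-bond donors, gives a 1.5-fold lower number from compound 3 to compound 4 (0.18 log units; within the scatter), so the two groups cannot be told apart here. Nor does a ring on this carbonyl carbon by itself leave a compound at the limit, as the non-aromatic oxan-3-yl ring differs from the furan-2-yl ring by an at least 3.3-fold lower number from compound 1 to compound 4 (0.52 log units; beyond the scatter), and it also differs from the shorter hydroxyl-bearing chain by an at least 3.3-fold lower number from compound 2 to compound 4 (0.52 log units; beyond the scatter). The true size of these last two steps cannot be read, because both rest on a limit: the limit of > 100000 nM in this assay, at which 2 of the 4 values shown sit.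

The compounds shown leave open whether the ring oxygen of oxan-3-yl matters at all, which a cyclohexyl ester would test, and whether its place in the ring counts, which an oxan-4-yl ester would show. They also leave open how a ring carrying an amine, such as a piperidine, would read in this assay, and whether any group at this place reaches much lower numbers than those of compound 3 and compound 4.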